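Methyl to Methoxy on the Aryl Ring: a Second Instance

A few compounds are considered here, and "the series" means these few. Any claim that something is new, unique, unknown or untested is made for them only; others in the source may bear on it.

Compound 1 `CCOC(=O)c1csc2nc(CN3CCN(C)CC3)c(-c3ccc(C)cc3)n12`: 58300 nM
Compound 2 `CCOC(=O)c1csc2nc(CN3CCN(C)CC3)c(-c3ccc(OC)cc3)n12`: 32800 nM
Compound 3 `Cc1ccc(-c2c(CN3CCCCC3)nc3scc(C(=O)O)n23)cc1`: 8290 nM

Of the compounds shown here, three have been measured in a functional assay on MCF7 cells (Homo sapiens) for antiproliferative activity, read by MTT assay, with a stated time of 72 h; on this read-out higher numbers stand for weaker inhibition and lower numbers for stronger inhibition. Compound 1 `CCOC(=O)c1csc2nc(CN3CCN(C)CC3)c(-c3ccc(C)cc3)n12` gives 58300 nM, and compound 2 `CCOC(=O)c1csc2nc(CN3CCN(C)CC3)c(-c3ccc(OC)cc3)n12`, which carries the change (methoxy in place of methyl on an aromatic carbon), gives 32800 nM. That single change made a step of a 1.8-fold lower number from compound 1 to compound 2 (0.25 log units; within the scatter). Compound 3 `Cc1ccc(-c2c(CN3CCCCC3)nc3scc(C(=O)O)n23)cc1` gives 8290 nM, the lowest of the three numbers; the difference between its core and that of compound 1 is not broken down here.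

Compound 4 `COc1ccc(-c2c(CN3CCCCC3)nc3scc(C(=O)O)n23)cc1` has not yet been measured. It differs from compound 3 by methoxy in place of methyl on an aromatic carbon, the same kind of change as that from compound 1 to compound 2, made on the same kind of place. On the basis of the earlier step of a 1.8-fold lower number from compound 1 to compound 2 (0.25 log units; within the scatter), a step of similar size, a 1.4-fold lower number from compound 3 to compound 4 (0.14 log units; within the scatter), is expected from compound 3 to compound 4 in this assay, a step that stays within the scatter. The value of compound 4 is therefore estimated at 6000 nM, with a likely range from 2000 nM to 20000 nM.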

Compound 4, half-maximal inhibitory concentration: 62900 nM
For compound 4 the middle estimate is 10-fold (1.02 log units) below the measured one; measured number above the stated range.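

In this assay, the change from 4-methylphenyl to 4-methoxyphenyl gave a 7.6-fold higher number from compound 3 to compound 4 (0.88 log units; beyond the scatter), so the step seen on the core of compound 1 did not carry over to the core of compound 3, and the two steps differ by more than the scatter allows: the same change on two cores in this assay, a 1.8-fold lower number (0.25 log units; within the scatter) from compound 1 to compound 2 and a 7.6-fold higher number (0.88 log units; beyond the scatter) from compound 3 to compound 4, 13-fold (1.13 log units) apart, beyond the scatter of two such steps

On these two pairs, then, the earlier step was a poor guide to the later one, and the effect of this change on the read-out depended on the core that carried it. Within the data shown here, the result does not show which structural difference between the two cores is responsible, nor does it establish a rule for other cores, as it rests on only two pairs.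

The compounds shown leave open whether the carboxylic acid or the basic side chain, taken alone, decides the outcome of the change. They also leave open how an amine or a longer alkoxy chain in place of methoxy would behave on the core of compound 3.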